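The source may hold more compounds than are shown below. What is called first, only, known or untested is meant among the compounds shown, and "the series" means these compounds.

Measured so far:
compound 1, `C=Cn1c2ccc([N+](=O)[O-])cc2c(=O)n1Cc1ccccc1`: 160000 nM
compound 2, `CNC(=O)CCCn1c2ccc([N+](=O)[O-])cc2c(=O)n1Cc1ccccc1`: > 256000 nM, a limit of the test

In an ADME assay on L929 cells (Mus musculus) for cytotoxicity, read by resazurin assay, with a stated time of 48 h (on this read-out higher numbers stand for lower toxicity in this test and lower numbers for higher toxicity in this test), compound 1 gives 160000 nM, the only number shown. Compound 2 gives in this assay only the limit > 256000 nM. Compound 3, `CC(=O)n1c2ccc([N+](=O)[O-])cc2c(=O)n1Cc1ccccc1`, differs from compound 1 by acetyl in place of vinyl on an aromatic nitrogen. Within the data shown here, the single measured step that bears on it, an at least 1.6-fold higher number from compound 1 to compound 2 (0.20 log units; that floor lies within the scatter), also replaced vinyl on an aromatic nitrogen and sat within the scatter, so no shift beyond the scatter is expected here. Compound 3 is therefore estimated at 180000 nM, between 80000 nM and 400000 nM, an expected 1.1-fold higher number from compound 1 to compound 3 (0.05 log units; within the scatter).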

Compound 3, concentration lethal to 50% of the cells: > 256000 nM
Compound 3 was reported as a limit; the forecaster's own chance of this, stated with the estimate: 30%; middle value at least 1.4-fold (0.15 log units) away from the limit.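

In this assay, acetyl on the aromatic nitrogen is a second replacement for vinyl, after 3-(methylcarbamoyl)propyl, that is reported only as a limit, so this outcome is not confined to the longer chain. The change gives an at least 1.6-fold higher number from compound 1 to compound 3 (0.20 log units; that floor lies within the scatter), so the floor alone does not separate the two compounds beyond the scatter. The step between compound 2 and compound 3 cannot be read, since both values are limits: the limit of > 256000 nM in this assay, at which 2 of the 3 values shown sit.

From the compounds shown here alone, it remains open whether an amine or a carboxylic acid on this nitrogen would give a number rather than a limit. Going by these compounds, the true values of compound 2 and compound 3 also remain open.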